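A few compounds are considered here, and "the series" means these few. Any claim that something is new, unique, unknown or untested is made for them only; others in the source may bear on it.

Measured compounds:
Compound 1 `COc1cc(C)c(-c2cccc(COc3ccc(S(=O)(=O)CC(=O)O)cc3)c2)c(C)c1` — in a functional assay on CHO cells for agonist activity at Free fatty acid receptor 1 (Homo sapiens), read by FLIPR and calcium flux (a higher number here means that more compound is needed for the effect, a lower number that less compound is needed), compound 1 gives 57.5 nM.
Compound 2 `Cc1ccccc1-c1cccc(COc2ccc(S(=O)(=O)CC(=O)O)cc2)c1` — compound 2 gives 46.8 nM.
Compound 3 `O=C(O)CS(=O)(=O)c1ccc(OCc2cccc(-c3ccccc3Cl)c2)cc1` — compound 3 gives 28.8 nM.

Among these three, compound 1 carries the highest number, but every gap to it lies within the usual scatter: a 1.2-fold lower number from compound 1 to compound 2 (0.09 log units; within the scatter) and a 2.0-fold lower number from compound 1 to compound 3 (0.30 log units; within the scatter). The two remaining compounds sit close to each other as well, with a 1.6-fold lower number from compound 2 to compound 3 (0.21 log units; within the scatter). Taken together, the three measured compounds describe a narrow band in which none can be called stronger or weaker than another.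

Compound 4 `COc1cc(C)c(-c2cccc(COc3ccc(S(=O)(=O)C(C)(C)C(=O)O)cc3)c2)c(C)c1` is the unmeasured compound. It differs from compound 1 in one place: 1-carboxy-1-methylethyl in place of carboxymethyl on a sulfonyl sulfur. For the measured compounds named here, all three measured steps alter the aryl group at the far end of the shared core and leave the group on the sulfonyl sulfur untouched, so no measured step speaks to the change from compound 1 to compound 4. Without such a step, the expectation for compound 4 rests on compound 1 alone, with the direction of any shift left open and the range set wider than usual. Compound 4 is therefore estimated at 55 nM, with a range from 15 nM to 220 nM. That estimate corresponds to an expected 1.0-fold lower number from compound 1 to compound 4 (0.02 log units; within the scatter).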

Compound 4, half-maximal effective concentration: > 1000 nM
Compound 4: a limit, no number; the forecaster's own chance of this, stated with the estimate: 5%; at least 18-fold (1.25 log units) between middle value and limit.
By their numbers in this assay, from the lowest: compounds 3, 2 and 1 (each within the scatter of the next). At a limit, above all of these: compound 4.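

For the compounds shown here, the group on the sulfonyl sulfur matters in this assay, which the earlier compounds could not show, since all three carry carboxymethyl there and differ only in the aryl group: 1-carboxy-1-methylethyl in place of carboxymethyl gives an at least 17-fold higher number from compound 1 to compound 4 (1.24 log units; beyond the scatter). Compound 4 stands at a limit of the assay and not at a number: the limit of > 1000 nM in this assay, at which 1 of the 4 values shown sits. The change adds only carbon, taking the group from 4 to 6 heavy atoms with the same counts of hydrogen-bond donors and acceptors, yet this step lies beyond the scatter, whereas every step among compounds 1, 2 and 3 lies within it.

The compounds shown leave open whether a smaller change on the same carbon, such as 1-carboxyethyl with a single methyl group, would be enough to produce such a step, and whether a longer chain such as 2-carboxyethyl on the sulfonyl sulfur would do the same. They also leave open whether the same exchange would give a step of this kind with the 2-methylphenyl or 2-chlorophenyl group of compounds 2 and 3.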